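This account rests on a few compounds, and the source may have more. Where it says the series, first, only, none or still open, it means among the compounds named here.

Four nucleoside analogues built on one shared core are compared here in an ADME assay on BJ cells (Homo sapiens), read by MTT assay, with a stated time of 72 h; on this read-out higher numbers stand for weaker inhibition and lower numbers for stronger inhibition. Compound 1 `CSc1ncnc2c1c(-c1ccccc1)cn2[C@@H]1O[C@H](CO)[C@@H](O)[C@H]1O` gives in this assay > 100000 nM, which is a limit of the assay rather than a number. Compound 2 `COc1ncnc2c1c(-c1ccccc1)cn2[C@@H]1O[C@H](CO)[C@@H](O)[C@H]1O` likewise gives in this assay > 100000 nM, again a limit. For the measured compounds named here, compound 3 `C#Cc1cn([C@@H]2O[C@H](CO)[C@@H](O)[C@H]2O)c2ncnc(OC)c12` is the only one with a number, giving in this assay 98400 nM. The change from compound 2 to compound 3 is ethynyl in place of phenyl on an aromatic carbon, and the step of an at least 1.0-fold lower number from compound 2 to compound 3 (0.00 log units; that floor lies within the scatter) is all that the two values allow. The change from compound 2 to compound 1 is methylsulfanyl in place of methoxy on an aromatic carbon; its step that the two limits leave unreadable from compound 2 to compound 1 cannot be sized because of the limit of > 100000 nM in this assay, at which 2 of the 3 values shown sit.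

Compound 4 `C#Cc1cn([C@@H]2O[C@H](CO)[C@@H](O)[C@H]2O)c2ncnc(SC)c12` is not yet measured. It differs from compound 3 by methylsulfanyl in place of methoxy on an aromatic carbon, the same change as from compound 2 to compound 1, made on a core that differs from that of compound 2 as described for compound 3. With compound 3 sitting close to the limit, and the earlier step unreadable, the expected step for compound 4 is a 1.1-fold higher number from compound 3 to compound 4 (0.05 log units; within the scatter). The estimate for compound 4 in this assay is therefore 110000 nM, within 45000 nM to 300000 nM.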

Compound 4, half-maximal inhibitory concentration: 68600 nM
Estimate against measurement, compound 4: 1.6-fold (0.21 log units) above; low and high end bracket the measured number.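

In this assay, methylsulfanyl in place of methoxy on the ethynyl-bearing core now has a readable size, a 1.4-fold lower number from compound 3 to compound 4 (0.16 log units; within the scatter), and ethynyl in place of phenyl on the methylsulfanyl-bearing core is bounded as an at least 1.4-fold lower number from compound 1 to compound 4 (0.16 log units; that floor lies within the scatter). This second change has thus been followed on two cores, yet both steps are only floors, so the series does not show that it carries over with the same size, nor that its size differs between the cores: the same change on two cores in this assay, an at least 1.0-fold lower number (0.00 log units; that floor lies within the scatter) from compound 2 to compound 3 and an at least 1.4-fold lower number (0.16 log units; that floor lies within the scatter) from compound 1 to compound 4; the limit leaves it open whether they differ The methylsulfanyl change cannot be followed from one core to another, since its step between the two phenyl-bearing compounds cannot be read, and neither can any other step that rests on two limits: the limit of > 100000 nM in this assay, at which 2 of the 4 values shown sit.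

The compounds shown leave open what an amine or a longer chain would give in place of methoxy or methylsulfanyl on this aromatic carbon. They also leave open what a methyl group or a nitrile would give in place of ethynyl or phenyl on the shared core.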